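Moving the Bromine: From Compound 2 to Compound 3

The compounds below may be only part of what the source reports. "The series", "measured", "known", "first", "only" and "open" are said of these compounds alone.

Compound 1, `Fc1cccc(Nc2nc(-c3cccc(F)c3)nc3ccc(F)cc23)c1`: 42300 nM in a functional assay on U-937 cells (Homo sapiens) for cytotoxicity, read by MTT assay, with a stated time of 48 h; a lower number here means a stronger inhibitor, a higher number a weaker inhibitor.
Compound 2, `Fc1cccc(-c2nc(Nc3ccc(Br)cc3)c3cc(F)ccc3n2)c1`: > 50000 nM, which is a limit of this assay and not a number.

Compound 2 therefore stands at the limit of > 50000 nM in this assay, at which 1 of the 2 values shown sits, a limit only. The change to compound 3, `Fc1cccc(-c2nc(Nc3cccc(Br)c3)c3cc(F)ccc3n2)c1`, is 3-bromophenyl in place of 4-bromophenyl on a nitrogen on an aromatic ring. Within the data shown here, the one measured step, an at least 1.1-fold higher number from compound 1 to compound 2 (0.07 log units; that floor lies within the scatter), also exchanged the group on that nitrogen and gave a rise whose floor sits within the scatter. Among the measured compounds shown here, no measured step moves a bromine between positions, so no shift beyond the scatter is expected in this assay. The expected step is a number no higher from compound 2 to compound 3 (the limit leaves the size open). Compound 3 is estimated at 50000 nM, within 20000 nM to 150000 nM, and a limit is again likely.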

Compound 3, half-maximal inhibitory concentration: > 50000 nM
Compound 3: no number, only a limit (the forecaster's own chance of this, stated with the estimate: 65%); the middle value lies on the limit itself.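

Compound 3 gives only a limit in this assay and not a number, and the step from compound 2 cannot be read, since both values are limits. Against compound 1, bromo in place of fluoro on an aromatic carbon gives an at least 1.1-fold higher number from compound 1 to compound 3 (0.07 log units; that floor lies within the scatter) and so establishes no shift beyond the scatter. Both bromophenyl groups on that nitrogen now end at the same limit: the limit of > 50000 nM in this assay, at which 2 of the 3 values shown sit.

Going by these compounds, whether the position of the bromine matters at all remains unknown. Also open, on these data alone, is whether an amine or a carboxylic acid in place of the bromine would bring a readable number.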